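The source may report more compounds than this note shows. Statements on the series, on what has been measured and on what is new or still open speak of the compounds shown alone.

In a functional assay on RAW264.7 cells (Mus musculus) for inhibition, read by ELISA, with stated times of 30 min and 24 h (on this read-out higher numbers stand for weaker inhibition and lower numbers for stronger inhibition), two compounds sharing one core have been measured. Compound 1 `CC(=O)OCC[C@@H](C)CC[C@@H]1[C@@]2(C)CCCC(C)(C)[C@@H]2CC[C@@]1(C)O` gives 25000 nM, and compound 2 `COC(=O)C[C@@H](C)CC[C@@H]1[C@@]2(C)CCCC(C)(C)[C@@H]2CC[C@@]1(C)O` gives 10000 nM. Going by the values given here, the only step between them is a 2.5-fold lower number from compound 1 to compound 2 (0.40 log units; beyond the scatter), a change at the end of the side chain. Compound 2 thus stands at the lowest of the two numbers, with compound 1 the nearest at a higher one.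

Compound 3 `C[C@H](CC=O)CC[C@@H]1[C@@]2(C)CCCC(C)(C)[C@@H]2CC[C@@]1(C)O` has not been measured in this assay. It differs from compound 2 by hydrogen in place of methoxy on a carbonyl carbon. Among the compounds with values here, no measured step alters the carbonyl carbon in this way, so nothing bears on it directly; the one step that exists, a 2.5-fold lower number from compound 1 to compound 2 (0.40 log units; beyond the scatter), only shows that a change at the chain end can move the number modestly. On that basis the author expects no more than a modest step in this assay for compound 3, in either direction, and most likely one within the scatter.

The estimate for compound 3 is 10000 nM, with a range from 3500 nM to 30000 nM, which would mean no change at the digits printed from compound 2 to compound 3 (within the scatter).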

Compound 3, half-maximal inhibitory concentration: > 50000 nM
Compound 3 gave a limit, no number (the forecaster's own chance of this, stated with the estimate: 10%); middle value at least 5.0-fold (0.69 log units) away from the limit.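

In this assay compound 3 stands at a limit and not at a number: the limit of > 50000 nM in this assay, at which 1 of the 3 values shown sits. Even so, the change of methoxycarbonyl to formyl, hydrogen in place of methoxy on a carbonyl carbon, gives an at least 5.0-fold higher number from compound 2 to compound 3 (0.69 log units; beyond the scatter). This shows that the carbonyl carbon at the chain end does not tolerate every replacement of methoxy, and that inhibition can weaken here by more than the earlier step at this end of the chain, a 2.5-fold lower number from compound 1 to compound 2 (0.40 log units; beyond the scatter), had shown, whereas the comparison with the acetoxymethyl chain end is less firm, at an at least 2.0-fold higher number from compound 1 to compound 3 (0.30 log units; that floor lies within the scatter), so compound 1 and compound 3 cannot be placed in order from these data.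

From the compounds shown here alone, how far compound 3 really lies from compound 2 stays unknown, since only a floor for that step can be read. Going by these compounds, it also remains open whether a carboxylic acid or an amide in place of the methoxycarbonyl would hold the number of compound 2 or move it towards the limit, and whether a longer chain carrying the methoxycarbonyl would shift it at all.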